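Swapping the aryl group of compound 1

The source may hold more compounds than are shown below. What is called first, only, known or untested is meant among the compounds shown, and "the series" means these compounds.

In an ADME assay on BJ cells (Homo sapiens) for cytotoxicity, with a stated time of 72 h (on this read-out lower numbers stand for an effect already at smaller amounts and higher numbers for an effect only at larger amounts of compound), compound 1 (`Cc1cc(NC(=O)Nc2ccc(F)cc2)c2ccccc2n1`) gives > 25000 nM as a limit and not a number. Compound 2 (`Cc1cc(NC(=O)Nc2ccc(SC(F)(F)F)cc2)c2ccccc2n1`) gives > 25000 nM as a limit too. Compound 3 (`Cc1cc(NC(=O)Nc2ccc(F)cc2F)c2ccccc2n1`) gives 20000 nM as a true number.

Compound 4 (`Cc1cc(NC(=O)Nc2ncccc2C)c2ccccc2n1`) carries 3-methylpyridin-2-yl in place of 4-fluorophenyl on an amide-type nitrogen. Two measured changes on the group being replaced bear on this swap. One is a step that the two limits leave unreadable from compound 1 to compound 2 and the other is an at least 1.2-fold lower number from compound 1 to compound 3 (0.09 log units; that floor lies within the scatter) in size. Neither shows a clear move, though neither introduces a pyridine. The expected step (a number no higher from compound 1 to compound 4 (the limit leaves the size open)) is therefore none beyond the scatter. For compound 4 the estimated value is 25000 nM with an expected range from 12000 nM to 50000 nM at this end of the assay.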

Compound 4, half-maximal effective concentration: > 25000 nM
Compound 4 gave a limit, no number; the forecaster's own chance of this, stated with the estimate: 65%; the middle value lies on the limit itself.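

No step can be read from compound 1 to compound 4, since each gives only a limit and no number: the limit of > 25000 nM in this assay, at which 3 of the 4 values shown sit. Going by these compounds, whether 3-methylpyridin-2-yl or 4-fluorophenyl goes with an effect at smaller amounts stays open.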